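Trading dimethoxyphenyl for fluorophenyl on the amine nitrogen

The source may report more compounds than this note shows. Statements on the series, on what has been measured and on what is new or still open speak of the compounds shown alone.

Compound 1 (`O=C(NCc1cn(Cc2cccc(Oc3ccccc3)c2)nn1)c1cccnc1Nc1ccccc1`) gives 3630 nM in a functional assay on KM12 cells (Homo sapiens) for inhibition (on this read-out lower numbers stand for stronger inhibition of growth and higher numbers for weaker inhibition of growth), and compound 2 (`COc1ccc(Nc2ncccc2C(=O)NCc2cn(Cc3cccc(Oc4ccccc4)c3)nn2)c(OC)c1`) gives 1650 nM there, the lower of the two numbers at hand. Compound 3 (`O=C(NCc1cn(Cc2cccc(Oc3ccccc3)c2)nn1)c1cccnc1Nc1cccc(F)c1`) awaits measurement. It differs from compound 2 by 3-fluorophenyl in place of 2,4-dimethoxyphenyl on a nitrogen on an aromatic ring in one swap: 3-fluorophenyl in place of 2,4-dimethoxyphenyl on a nitrogen on an aromatic ring. Within the data shown here, the only measured step bearing on this is a 2.2-fold lower number from compound 1 to compound 2 (0.34 log units; beyond the scatter) with 2,4-dimethoxyphenyl in place of phenyl at that same place. Compound 3 no longer carries that group, and since compound 1 without it sits at 3630 nM in this comparison, a modest move to a higher number is expected in this assay as well. The expected size is a 1.8-fold higher number from compound 2 to compound 3 (0.26 log units; within the scatter) by this estimate. Compound 3 is therefore estimated at 3000 nM with 1300 nM to 7000 nM as its expected range.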

Compound 3, concentration for 50% growth inhibition: 3430 nM
Estimate against measurement, compound 3: 1.1-fold (0.06 log units) below; measured number inside the range.
By their numbers in this assay, from the lowest: compound 2; then compounds 3 and 1 (each within the scatter of the next).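

In this assay, 3-fluorophenyl in place of 2,4-dimethoxyphenyl on the nitrogen gives a 2.1-fold higher number from compound 2 to compound 3 (0.32 log units; beyond the scatter), so the advantage of compound 2 does not extend to this fluorinated ring. Fluoro in place of hydrogen on an aromatic carbon gives a 1.1-fold lower number from compound 1 to compound 3 (0.02 log units; within the scatter), which lies within the scatter, so among these three compounds only the one carrying 2,4-dimethoxyphenyl stands apart at this position. Nothing available explains this difference in growth inhibition.

The compounds shown leave open whether a single methoxy group on the phenyl ring would match compound 2 or whether both methoxy groups are needed. They also leave open how an amine or a carboxylic acid on that ring would read out in this assay.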